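This account rests on a few compounds, and the source may have more. Where it says the series, first, only, none or still open, it means among the compounds named here.

Measured compounds:
compound 1 `COc1ccc(NCc2nc3ccccc3[nH]2)cc1` with 7.6%
compound 2 `c1ccc(NCc2nc3ccccc3[nH]2)cc1` with 7.6%
compound 3 `O=[N+]([O-])c1ccc2nc(CNc3ccc(Br)cc3)[nH]c2c1` with 15.3%

In a functional assay on the whole organism (strain albino) for inhibition, with Rattus norvegicus as the target, read by paw edema, with a stated time of 30 min, at a dose of 100 mg/kg by the oral route (a lower number here means less inhibition, a higher number more inhibition at the dose given (going by the name of the read-out)), compound 3 gives the highest of the three numbers, yet compound 1 with 7.6% and compound 2 with 7.6% both lie within the scatter of it, so no order among the three can be read from these numbers. Compound 4 `Brc1ccc(NCc2nc3ccccc3[nH]2)cc1` has not yet been measured in this assay. It differs from compound 3 in one place: hydrogen in place of nitro on an aromatic carbon. Among the compounds with values here, the only measured step that bears on it, loosely, is the one from compound 1 to compound 2, also a hydrogen in place of a substituent on an aromatic carbon, where no change at the digits printed from compound 1 to compound 2 (within the scatter). Within the data shown here, that step sits on a different ring, and the nitro itself has no measured counterpart here, so the guidance is thin. On that basis compound 4 is expected to show a number 4.3 percentage points lower from compound 3 to compound 4 (within the scatter), a step not beyond the scatter. Compound 4 is therefore estimated at 11%, with a range from 0% to 24%.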

Compound 4, a percentage reported as inhibition, in the whole organism at one dose (the size of the read-out at that dose, not a potency): 7.6%
Compound 4: the middle estimate sits 3.4 percentage points above what was measured; low and high end bracket the measured number.
By their numbers in this assay, from the lowest: compounds 1, 2, 4 and 3 (each within the scatter of the next).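

Hydrogen in place of nitro, on an aromatic carbon of the six-membered ring of carbon only in the fused system of two rings, gives a number 7.7 percentage points lower from compound 3 to compound 4 (within the scatter) in this assay and is the first measured change at this position, where removing the nitro leaves no step beyond the scatter. On the other aromatic ring, bromo in place of hydrogen gives no change at the digits printed from compound 2 to compound 4 (within the scatter) and bromo in place of methoxy gives no change at the digits printed from compound 1 to compound 4 (within the scatter) in this assay so that hydrogen, methoxy and bromo cannot be told apart there. No evidence is available to account for these numbers.

From the compounds shown here alone, whether an amine or a carboxylic acid on that aromatic carbon of the fused system would shift the inhibition beyond the scatter remains open. So does whether a longer chain in place of bromo on the other ring would do so.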